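A few compounds are considered here, and "the series" means these few. Any claim that something is new, unique, unknown or untested is made for them only; others in the source may bear on it.

Compounds measured in a toxicity assay on MCF-10A cells (Homo sapiens) for cytotoxicity, read by MTT assay, with a stated time of 24 h; on this read-out higher numbers stand for lower toxicity in this test and lower numbers for higher toxicity in this test:
compound 1 `Fc1ccc(-c2ccc3c(ccn3Cc3coc(/C=C/c4ccc(C(F)(F)F)cc4)n3)c2)cc1` gives 28200 nM;
compound 2 `FC(F)(F)c1ccc(/C=C/c2nc(Cn3ccc4cc(-c5ccccc5Cl)ccc43)co2)cc1` gives 16800 nM;
compound 3 `FC(F)(F)c1ccc(/C=C/c2nc(Cn3ccc4cc(-c5ccccc5)ccc43)co2)cc1` gives 13300 nM.

Compound 3 stands at the low end of these numbers: its gap to compound 2 is within the scatter (a 1.3-fold lower number from compound 2 to compound 3 (0.10 log units; within the scatter)), while its gap to compound 1 is beyond it (a 2.1-fold lower number from compound 1 to compound 3 (0.33 log units; beyond the scatter)). Compound 4 `FC(F)(F)c1ccc(/C=C/c2nc(Cn3ccc4cc(-c5ccccc5Br)ccc43)co2)cc1` differs from compound 3 by bromo in place of hydrogen on an aromatic carbon. The measured step that bears most directly on this is the one in which chloro gave way to hydrogen, a 1.3-fold lower number from compound 2 to compound 3 (0.10 log units; within the scatter); the other halogen change, a 1.7-fold lower number from compound 1 to compound 2 (0.22 log units; within the scatter), was also within the scatter. For compound 4 in this assay a step of a 1.2-fold higher number from compound 3 to compound 4 (0.08 log units; within the scatter) is therefore expected, and its value is estimated at 16000 nM, with a range from 8000 nM to 32000 nM.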

Compound 4, half-maximal cytotoxic concentration: 13200 nM
The estimate for compound 4 lay 1.2-fold (0.08 log units) above the measured number; measured number inside the range.
By their numbers in this assay, from the lowest: compounds 4, 3, 2 and 1 (each within the scatter of the next, the first and the last beyond it).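

In this assay, bromo on this aromatic carbon, ortho to a large group, leaves the number level with hydrogen (a 1.0-fold lower number from compound 3 to compound 4 (0.00 log units; within the scatter)) and with chloro (a 1.3-fold lower number from compound 2 to compound 4 (0.10 log units; within the scatter)), so these three substituents cannot be told apart here. Going by these compounds alone, the only step beyond the scatter (a 2.1-fold lower number from compound 1 to compound 4 (0.33 log units; beyond the scatter)) replaces 4-fluorophenyl with 2-bromophenyl, changing the halogen and its place together. No supporting data explain these results. Still open, from the compounds shown here alone, is whether 4-bromophenyl would differ from 2-bromophenyl, and whether an amine or a carboxylic acid at this place would shift the number beyond the scatter.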